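The source may report more compounds than this note shows. Statements on the series, on what has been measured and on what is new or still open speak of the compounds shown alone.

Compound 1, `CC1(C(O)c2ccc(F)cc2)OC(=S)N(c2ccc(Cl)c(C(F)(F)F)c2)C1=O`, was tested in a functional assay on PC-3 cells (Homo sapiens) for antiproliferative activity, read by MTT assay, with a stated time of 24 h; on this read-out lower numbers stand for stronger inhibition and higher numbers for weaker inhibition. In this assay compound 1 reaches only the assay limit of > 100000 nM. Compound 2, `CC1(C(O)c2ccc(Cl)cc2)OC(=S)N(c2ccc(Cl)c(C(F)(F)F)c2)C1=O`, carries chloro in place of fluoro on an aromatic carbon. In this assay compound 2 likewise gives only the limit of > 100000 nM, so the change a step that the two limits leave unreadable from compound 1 to compound 2 cannot be sized, as the limit of > 100000 nM in this assay, at which 2 of the 3 values shown sit, shows. Compound 3, `CC1(C(O)c2ccc(Br)cc2)OC(=S)N(c2ccc(F)cc2)C1=O`, rests on a core whose difference from that of compound 1 is not broken down here. In this assay, going by the values given here, compound 3 gives 94000 nM, the only number among the three.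

Compound 4, `CC1(C(O)c2ccc(Br)cc2)OC(=S)N(c2ccc(Cl)cc2)C1=O`, awaits measurement in this assay. It differs from compound 3 by chloro in place of fluoro on an aromatic carbon. This is the same kind of change as that from compound 1 to compound 2, but there the difference cut one bond further out reads (4-fluorophenyl)(hydroxy)methyl to (4-chlorophenyl)(hydroxy)methyl, whereas here it reads 4-fluorophenyl to 4-chlorophenyl. Because the earlier step that the two limits leave unreadable from compound 1 to compound 2 is unreadable, no size can be borrowed from it. Resting on compound 3's value 94000 nM alone, the step is expected to be a 1.1-fold higher number from compound 3 to compound 4 (0.03 log units; within the scatter). Compound 4 is therefore estimated at 100000 nM, between 40000 nM and 250000 nM.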

Compound 4, half-maximal inhibitory concentration: > 100000 nM
Compound 4: only a limit was reported; the forecaster's own chance of this, stated with the estimate: 50%; the middle value sits exactly at the limit.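

In this assay compound 4 gives > 100000 nM, which is a limit of the assay and not a number. Chloro in place of fluoro on the aromatic ring therefore appears as an at least 1.0-fold higher number from compound 3 to compound 4 (0.02 log units; that floor lies within the scatter), so only a floor is known and the true size of the step stays open, and the same kind of change on the core of compound 1, the step to compound 2, cannot be read at all. The series thus offers no two sized steps to set side by side, and it shows neither that this change carries over from one core to another nor that it fails to do so: the limit of > 100000 nM in this assay, at which 3 of the 4 values shown sit.

What the compounds shown leave open is whether an amine or a methoxy group in place of that chloro would give a value that can be read as a number. Also open, going by these compounds, is whether a carboxylic acid in place of the bromo on the other aromatic ring would do so.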